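The source may hold more compounds than are shown below. What is called first, only, known or untested is meant among the compounds shown, and "the series" means these compounds.

Measured compounds:
Compound 1, `COc1ccccc1N1CCN(C(=O)CN2C(=O)CC(C)(c3ccccc3)C2=O)CC1`, in a functional assay on the whole organism (strain CD-1) with Mus musculus as the target, with a stated time of 2 h; a lower number here means that less compound is needed, a higher number that more compound is needed for the effect: "not active" (no number reported)
Compound 2, `CC1(c2ccccc2)CC(=O)N(CC(=O)N2CCN(c3ccc(F)cc3)CC2)C1=O`, in this assay: 300 mg/kg

For the measured compounds named here, compound 2 stands alone as the only number in this assay; compound 1 came back with no number at all, only a report of no activity. Compound 3, `CC1(c2ccccc2)CC(=O)N(CC(=O)N2CCN(c3cccc(C(F)(F)F)c3)CC2)C1=O`, has yet to be measured in this assay. It differs from compound 2 in one place: 3-(trifluoromethyl)phenyl in place of 4-fluorophenyl on an amine nitrogen in a ring. Going by the values given here, no pair of measured compounds differs in a single place, so no measured step exists to guide the expectation, and the estimate for compound 3 rests on compound 2 only. The step of no change at the digits printed from compound 2 to compound 3 (within the scatter) is expected to stay within the usual scatter, in no clear direction. Compound 3 is therefore estimated at 300 mg/kg in this assay, with a range from 100 mg/kg to 1000 mg/kg. Since compound 1 yielded no number, a report of no activity for compound 3 also remains possible.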

Compound 3, minimum effective dose: 300 mg/kg
The estimate for compound 3 equals the measured number at the digits printed; the range from low to high includes it.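

In this assay, for the compounds shown here, the exchange of 4-fluorophenyl for 3-(trifluoromethyl)phenyl on an amine nitrogen in a ring gives no change at the digits printed from compound 2 to compound 3 (within the scatter) and thus supplies the first readable step at this position. The position therefore carries a number with either of these two fluorine-bearing phenyl groups, although the entering group is the larger by heavy atoms. Compound 1 has no number, so steps involving it cannot be read.

The compounds shown leave open whether an unsubstituted phenyl, a pyridine ring or a simple alkyl chain on this nitrogen would also give a number in this assay and how far the minimum effective dose could fall from the value of compound 3, 300 mg/kg in that assay. Nothing available on this result offers an explanation for it.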